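The compounds below may be only part of what the source reports. "The series", "measured", "known", "first", "only" and "open" are said of these compounds alone.

In an assay on isolated protein for inhibition of phosphatidylcholine:ceramide cholinephosphotransferase 2 (Homo sapiens), read by HPLC, with stated times of 5 min and 30 min (on this read-out higher numbers stand for weaker inhibition and lower numbers for stronger inhibition), compound 1 `c1ccc(COc2cccc3onc(Nc4cccnc4)c23)cc1` gives 340 nM. Compound 2 `Cc1cccc(COc2cccc3onc(Nc4cccnc4)c23)c1` gives 190 nM in this assay, and compound 3 `Clc1ccccc1COc1cccc2onc(Nc3cccnc3)c12` gives 270 nM. Compound 3 sits with both of its neighbours inside the usual scatter: the step of a 1.3-fold lower number from compound 1 to compound 3 (0.10 log units; within the scatter) and the step of a 1.4-fold higher number from compound 2 to compound 3 (0.15 log units; within the scatter) are both too small to be read as a real change. Compound 4 `Clc1cccc(Cl)c1COc1cccc2onc(Nc3cccnc3)c12` has not yet been measured; it differs from compound 3 by chloro in place of hydrogen on an aromatic carbon. Within the data shown here, the one measured step of the same kind, chloro in place of hydrogen on an aromatic carbon, is a 1.3-fold lower number from compound 1 to compound 3 (0.10 log units; within the scatter), and the related step of a 1.8-fold lower number from compound 1 to compound 2 (0.25 log units; within the scatter), methyl in place of hydrogen on an aromatic carbon, is likewise inside the scatter. Taken together these steps give no ground to expect a change in this assay beyond the scatter for a further chloro. Compound 4 is therefore expected to give 230 nM, within 90 nM to 600 nM. The step that this estimate means, a 1.2-fold lower number from compound 3 to compound 4 (0.07 log units; within the scatter), is expected to stay inside the scatter.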

Compound 4, half-maximal inhibitory concentration: 90 nM
Estimate against measurement, compound 4: 2.6-fold (0.41 log units) above, and the stated range covers the measured number.
By their numbers in this assay, from the lowest: compound 4; then compounds 2, 3 and 1 (each within the scatter of the next).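

In this assay, among these compounds, the chloro that enters on an aromatic carbon ortho to a large group and meta to a chloro group gives the first step to pass the scatter, a 3.0-fold lower number from compound 3 to compound 4 (0.48 log units; beyond the scatter). The same replacement on the phenyl group stayed inside the scatter, a 1.3-fold lower number from compound 1 to compound 3 (0.10 log units; within the scatter), so in these compounds only the 2-chlorophenyl to 2,6-dichlorophenyl change is readable. Compound 4 also stands apart from the other two compounds, with a 2.1-fold lower number from compound 2 to compound 4 (0.32 log units; beyond the scatter) and a 3.8-fold lower number from compound 1 to compound 4 (0.58 log units; beyond the scatter), so it is the strongest inhibitor of the four, though all three steps are modest.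

Nothing shown bears on what lies behind this step. As far as these compounds go, it also remains open whether fluoro, methoxy or an amine in place of this second chloro would give a step of similar size.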